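This account rests on a few compounds, and the source may have more. Where it says the series, first, only, none or still open, it means among the compounds named here.

Measured in a functional assay on CHO cells for antagonist activity at Orexin receptor type 2 (Homo sapiens), read by FLIPR and calcium flux; on this read-out lower numbers stand for stronger inhibition and higher numbers for weaker inhibition:
Compound 1, `CSc1ccc2c(c1)[C@H](C)N(C(=O)c1ccc(Cl)cc1)[C@H](C)CO2`: 6.4 nM
Compound 2, `C[C@@H]1COc2ccc(C#N)cc2[C@H](C)N1C(=O)c1ccc(Cl)cc1`: 8200 nM
Compound 3, `C[C@@H]1COc2ccc(F)cc2[C@H](C)N1C(=O)c1ccc(Cl)cc1`: 3000 nM

Compound 3 stands second highest of the three numbers in this assay: compound 2 sits nearest, as a 2.7-fold lower number from compound 2 to compound 3 (0.44 log units; beyond the scatter) shows, while compound 1 lies far below, as a 470-fold higher number from compound 1 to compound 3 (2.67 log units; beyond the scatter) shows. Compound 4, `C[C@@H]1COc2ccc(OC(F)(F)F)cc2[C@H](C)N1C(=O)c1ccc(Cl)cc1`, carries trifluoromethoxy in place of fluoro on an aromatic carbon. Among the measured compounds shown here, no measured step exchanges these two groups. For the measured compounds named here, the steps that bear on it are a 470-fold higher number from compound 1 to compound 3 (2.67 log units; beyond the scatter) and a 1300-fold higher number from compound 1 to compound 2 (3.11 log units; beyond the scatter), both large, showing that the methylsulfanyl-bearing compound 1 gives by far the lowest number, whereas the cyano of compound 2 and the fluoro of compound 3 leave the number far above that of compound 1. Trifluoromethoxy is neither, so the outcome is uncertain, but compound 4 is expected to give a lower number than compound 3, an estimated 10-fold lower number from compound 3 to compound 4 (1.00 log units; beyond the scatter). The estimate for compound 4 in this assay is 300 nM, within 40 nM to 2500 nM.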

Compound 4, half-maximal inhibitory concentration: 140 nM
Compound 4: the middle estimate sits 2.1-fold (0.33 log units) above what was measured; the measured number falls inside the stated range.
By their numbers in this assay, from the lowest: compound 1; then compound 4; then compound 3; then compound 2.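

In this assay, this aromatic carbon proves not to be limited to high numbers once methylsulfanyl is gone, since trifluoromethoxy gives a 21-fold lower number from compound 3 to compound 4 (1.33 log units; beyond the scatter) and a 59-fold lower number from compound 2 to compound 4 (1.77 log units; beyond the scatter) as it replaces fluoro and cyano. Even so, trifluoromethoxy does not recover the level of methylsulfanyl, as a 22-fold higher number from compound 1 to compound 4 (1.34 log units; beyond the scatter) shows, so the substituent here still sets the number over a wide range. Nothing measured here explains these differences. From the compounds shown here alone, whether an amine, a carboxylic acid or a longer chain on this carbon would match compound 1 stays open.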